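The compounds below may be only part of what the source reports. "The series", "measured", "known", "first", "only" and "open" are said of these compounds alone.

Measured so far:
- compound 1 `CC1=NC(c2cn(S(=O)(=O)c3ccc(Cl)cc3)c3ccccc23)CN1`: 5700 nM
- compound 2 `CC1=NC(c2cn(S(=O)(=O)c3cccs3)c3ccc(C)cc23)CN1`: 11000 nM

In an assay on isolated protein for inhibition of kallikrein-7 (Homo sapiens), read by fluorescence, with stated times of 10 min and 30 min (on this read-out lower numbers stand for stronger inhibition and higher numbers for weaker inhibition), compound 2 gives the larger of the two numbers, yet its gap to compound 1 is within the scatter, so the two compounds do not separate on this read-out. Compound 3 `CC1=NC(c2cn(S(=O)(=O)c3c(Cl)cccc3Cl)c3ccc(C)cc23)CN1` carries 2,6-dichlorophenyl in place of thiophen-2-yl on a sulfonyl sulfur. Within the data shown here, no step between measured compounds touches this position; compound 1 shows that a chlorinated phenyl on the sulfonyl sulfur is tolerated. A modest lowering of the number, likely within the scatter, is expected: a 1.8-fold lower number from compound 2 to compound 3 (0.26 log units; within the scatter). Compound 3 is estimated at 6000 nM, between 2000 nM and 18000 nM.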

Compound 3, half-maximal inhibitory concentration: 14000 nM
Beside the measured number, compound 3's estimate is 2.3-fold (0.37 log units) below it; measured number inside the range.
By their numbers in this assay, from the lowest: compounds 1, 2 and 3 (each within the scatter of the next, the first and the last beyond it).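

In this assay, 2,6-dichlorophenyl in place of thiophen-2-yl on a sulfonyl sulfur gives a 1.3-fold higher number from compound 2 to compound 3 (0.10 log units; within the scatter), so compound 2 and compound 3 do not separate. On this read-out, the change from a five-membered aromatic ring with one hetero atom to a larger, chlorinated six-membered aromatic ring leaves the number within the scatter. No supporting data bear on why this swap leaves the result unresolved. Still open, on these data alone, is whether a phenyl carrying an amine or a carboxylic acid on the sulfonyl sulfur would move the number beyond the scatter.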